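The compounds below may be only part of what the source reports. "The series", "measured", "known", "first", "only" and "open" are said of these compounds alone.

Compound 1 `COc1cc(-c2ccnc3cc(-c4ccc(C(C)=O)cc4)nn23)cc(OC)c1OC` is tested in a functional assay on A549 cells (Homo sapiens) for inhibition, read by CCK-8 assay, with a stated time of 48 h (on this read-out higher numbers stand for weaker inhibition and lower numbers for stronger inhibition), where it gives 4100 nM. Among the numbers available it stands highest: compound 2 `COc1cc(-c2ccnc3cc(-c4ccc(-c5cnn(C)c5)cc4)nn23)cc(OC)c1OC` gives 1150 nM in this assay. Compound 3 `CCOC(=O)c1ccc(-c2cc3nccc(-c4cc(OC)c(OC)c(OC)c4)n3n2)cc1` reaches only a limit of the assay, > 10000 nM in this assay, and so offers no number. The not yet measured compound 4 `COc1cc(-c2ccnc3cc(-c4ccc5c(ccn5C)c4)nn23)cc(OC)c1OC` differs from compound 1 in one place: 1-methyl-1H-indol-5-yl in place of 4-acetylphenyl on an aromatic carbon. The step that bears on it most is a 3.6-fold lower number from compound 1 to compound 2 (0.55 log units; beyond the scatter), where a 1-methyl-1H-pyrazol-4-yl ring likewise took the place of the acetyl. The steps of an at least 2.4-fold higher number from compound 1 to compound 3 (0.38 log units; beyond the scatter) and an at least 8.6-fold higher number from compound 2 to compound 3 (0.93 log units; beyond the scatter) point the other way, toward a weaker result when ethoxycarbonyl is brought in, but compound 4 carries no such group. Going from acetyl to 1-methyl-1H-indol-5-yl is therefore expected to move the number down by a modest amount, in the direction seen for compound 2. Compound 4 is expected to give 1500 nM, with a range from 600 nM to 4000 nM. That expectation corresponds to a step of a 2.7-fold lower number from compound 1 to compound 4 (0.44 log units; beyond the scatter).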

Compound 4, half-maximal inhibitory concentration: 15 nM
Compound 4: the middle estimate sits 100-fold (2.00 log units) above what was measured; measured number below the stated range.
By their numbers in this assay, from the lowest: compound 4; then compound 2; then compound 1. At a limit, above all of these: compound 3.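

In this assay, among the compounds shown here, the step of a 270-fold lower number from compound 1 to compound 4 (2.44 log units; beyond the scatter) is far larger than the step of a 3.6-fold lower number from compound 1 to compound 2 (0.55 log units; beyond the scatter) at the same place, so this aromatic carbon of the five-membered ring can shift the number much further than the earlier compounds showed. Compounds 1, 2 and 3 all keep a six-membered carbon ring here and vary only what it carries, whereas compound 4 shows that replacing that whole unit with the fused 1-methyl-1H-indol-5-yl is tolerated and gives the lowest number of the set. Nothing shown here explains why this change has so large an effect.

On these data alone, it remains open whether the methyl on the indole nitrogen matters, or whether an indole joined through another ring carbon would behave alike. Also open, as far as these compounds go, is how an amine or a carboxylic acid on the six-membered ring would compare with the acetyl.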